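Series notes: compound 4 after three assay limits

The source may report more compounds than this note shows. Statements on the series, on what has been measured and on what is new or still open speak of the compounds shown alone.

Three members of the series have been measured in an ADME assay on A2780 cells (Homo sapiens) for cytotoxicity (a lower number here means a stronger inhibitor, a higher number a weaker inhibitor), and none of them gives a number. Compound 1 `O=C(OC[C@H]1O[C@@H](OC[C@H](O)[C@@H](O)c2ccc(O)cc2)[C@H](O)[C@@H](O)[C@@H]1O)c1ccccc1` reaches only the limit, > 10000 nM. Compound 2 `O=C(OC[C@H]1O[C@@H](O[C@@H](C(=O)O)c2ccccc2)[C@H](O)[C@@H](O)[C@@H]1O)c1ccccc1` also sits at the limit, > 10000 nM. Compound 3 `O=C(OC[C@H]1O[C@@H](OC[C@H]2O[C@@H](OC(=O)c3ccccc3)[C@H](O)[C@@H](O)[C@@H]2O)[C@H](O)[C@@H](O)[C@@H]1O)c1ccccc1` likewise stops at the limit, > 10000 nM. Within the data shown here, compound 2 therefore stands exactly where every measured member stands, at the limit of > 10000 nM in this assay, at which 3 of the 3 values shown sit, with no number that would set it apart from compound 1 or compound 3, and no step between measured compounds has been resolved.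

Compound 4 `COc1cc(CO)ccc1O[C@@H]1O[C@H](COC(=O)c2ccccc2)[C@@H](O)[C@H](O)[C@H]1O` keeps the shared core and differs from compound 2 at one place: 4-(hydroxymethyl)-2-methoxyphenyl in place of carboxy(phenyl)methyl on an oxygen on a saturated carbon. Among the measured compounds shown here, nothing measured so far shows any change at that position moving a value off the limit.

For the measured compounds named here, with three limits and no resolved step, no direction can be read for the change in this assay; the expected step that the limit leaves unreadable from compound 2 to compound 4 is none beyond the scatter, and the most likely outcome is a fourth limit. Compound 4 is accordingly estimated at 15000 nM in this assay, with an expected range from 5000 nM to 50000 nM.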

Compound 4, half-maximal inhibitory concentration: > 10000 nM
Compound 4: a limit, no number (the forecaster's own chance of this, stated with the estimate: 85%); the middle value is on the limit's open side.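

In this assay compound 4 gives > 10000 nM as a limit, not a number. Among these compounds, compound 2 also gives only a limit, so no step from compound 2 to compound 4 can be read: the limit of > 10000 nM in this assay, at which 4 of the 4 values shown sit. The compounds shown leave open whether any change on the shared core moves a value off the limit.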